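Cyclopropyl for ethyl on the piperazine nitrogen: permeability notes

The source may hold more compounds than are shown below. What is called first, only, known or untested is meant among the compounds shown, and "the series" means these compounds.

The series shares one core; the three measured compounds are compound 1 `c1ccc2c(c1)CN[C@H](CN(CCCN1CCNCC1)[C@H]1CCCc3cccnc31)C2`, compound 2 `CCN1CCN(CCCN(C[C@H]2Cc3ccccc3CN2)[C@H]2CCCc3cccnc32)CC1` and compound 3 `CN1CCN(CCCN(C[C@H]2Cc3ccccc3CN2C)[C@H]2CCCc3cccnc32)CC1`. In an ADME assay for permeability, using PAMPA, with a stated time of 4 h, at pH 7.4 (a higher number here means that the compound crosses the layer faster, a lower number that the compound crosses the layer more slowly), compound 1 gives 16 nm/s, compound 2 gives 317 nm/s and compound 3 gives 513 nm/s. On these numbers compound 2 stands second of three. Its nearest neighbour is compound 3, and that difference lies within the scatter, so no order can be read between compound 2 and compound 3. Its furthest neighbour is compound 1, which stands beyond the scatter below compound 2. Within the data shown here, no pair of measured compounds differs in a single place, so no single measured step exists in this set.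

Compound 4 `c1ccc2c(c1)CN[C@@H](CN(CCCN1CCN(C3CC3)CC1)[C@H]1CCCc3cccnc31)C2` has not yet been measured in this assay. It differs from compound 2 in one place: cyclopropyl in place of ethyl on an amine nitrogen in a ring. Among the measured compounds shown here, compound 3 carries methyl on that same ring nitrogen but differs from compound 2 in a second place as well, so no measured step isolates this position. The step from compound 2 to compound 4 is expected to be a 1.1-fold higher number from compound 2 to compound 4 (0.04 log units; within the scatter), within the scatter, with no direction claimed. Compound 4 is expected to give 350 nm/s in this assay, with a range from 150 nm/s to 800 nm/s.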

Compound 4, apparent permeability: 505 nm/s
Estimate against measurement, compound 4: 1.4-fold (0.16 log units) below; measured number inside the range.
By their numbers in this assay, from the lowest: compound 1; then compounds 2, 4 and 3 (each within the scatter of the next).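

In this assay, among these compounds, cyclopropyl in place of ethyl on an amine nitrogen in a ring gives a 1.6-fold higher number from compound 2 to compound 4 (0.20 log units; within the scatter) and is the first measured step that isolates this position. At this scatter, 4-ethylpiperazin-1-yl and 4-cyclopropylpiperazin-1-yl cannot be told apart, and no order can be read between compound 2 and compound 4, even though the entering group carries one more carbon and a three-membered ring. Compound 3 also carries a carbon group on this nitrogen but differs from compound 2 in a second place, so only the new pair shows that this exchange, taken alone, leaves the read-out within the scatter. The data at hand offer no measured reason for this result.

The compounds shown leave open how a longer chain, a tert-butyl group or an amide carbonyl on this same nitrogen would read in this assay. They also leave open whether cyclopropyl and ethyl would stay within the scatter of each other in a compound that also carries methyl on the other ring nitrogen, as compound 3 does.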